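Benzylamine variation on a diaminoquinoxaline-type cytotoxic series

The source may hold more compounds than are shown below. What is called first, only, known or untested is meant among the compounds shown, and "the series" means these compounds.

Measured compounds:
- compound 1, `CCOC(=O)[C@H](CCC(=O)O)NC(=O)c1ccc(CNc2nc3cc(N)cc(N)c3nc2-c2ccccc2)cc1`, < 100000 nM
- compound 2, `Nc1cc(N)c2nc(-c3ccccc3)c(NCc3ccc(Cl)c(Cl)c3)nc2c1`, 69200 nM
- compound 3, `CCOC(=O)[C@H](CCC(=O)O)NC(=O)c1ccc(Oc2nc3cc(N)cc(N)c3nc2-c2ccccc2)cc1`, < 100000 nM

Of the compounds shown here, three sharing one core have been tested in a functional assay on A549 cells (Homo sapiens) for inhibition, read by sulforhodamine B assay, with a stated time of 48 h; a higher number here means that more compound is tolerated, a lower number that less compound is tolerated. Going by the values given here, compound 2 is the only one with a number: it gives 69200 nM. For compound 1 the result is a limit of the assay, < 100000 nM. For compound 3 the result is likewise a limit, < 100000 nM. So compound 2 is the single fixed point on which any comparison must rest, and the limit of < 100000 nM in this assay, at which 2 of the 3 values shown sit, marks where the other two sit.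

Compound 4, `Nc1cc(N)c2nc(-c3ccccc3)c(NCc3ccc(F)cc3)nc2c1`, has not yet been measured in this assay. It differs from compound 2 in one place: 4-fluorophenyl in place of 3,4-dichlorophenyl on a saturated chain carbon bound to a nitrogen on an aromatic ring. Among the compounds with values here, no step between two measured compounds is available to calibrate this change, since compounds 1 and 3 are limits and differ from compound 2 in another part of the molecule.

Compound 4 is therefore expected to lie close to compound 2, with a step from compound 2 to compound 4 of a 1.3-fold higher number from compound 2 to compound 4 (0.11 log units; within the scatter), leaning toward more compound being tolerated, and not clearly beyond the scatter. The estimate for compound 4 in this assay is 90000 nM, within a range from 40000 nM to 200000 nM.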

Compound 4, concentration lethal to 50% of the cells: 69200 nM
For compound 4 the middle estimate is 1.3-fold (0.11 log units) above the measured one; the range from low to high includes it.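

In this assay, going by these compounds alone, the earlier compounds offered one number and two limits, so they showed nothing about how the reading responds to a change at this position. The new pair gives the first such reading: with 4-fluorophenyl in place of 3,4-dichlorophenyl on a saturated chain carbon bound to a nitrogen on an aromatic ring, there is no change at the digits printed from compound 2 to compound 4 (within the scatter). At this position, then, the two chlorines can give way to a single fluorine without the reading leaving the scatter, though this rests on one pair alone, and the result must be read alongside the only other kind of outcome shown: the limit of < 100000 nM in this assay, at which 2 of the 4 values shown sit.

Within the data shown here, compound 1 and compound 3 each carry a limit of the assay, and no steps to them can be read. Going by these compounds, whether a methoxy group or a nitrile on the phenyl ring, or a longer chain in place of the benzyl carbon, would leave the reading equally unmoved remains open.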